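The compounds below may be only part of what the source reports. "The series", "measured", "known", "first", "only" and "open" are said of these compounds alone.

Of the compounds shown here, three from this series have been measured in an assay on isolated protein for binding affinity to cysteinyl leukotriene receptor 1 (Cavia porcellus); a lower number here means a less potent compound, a higher number a more potent compound, by a factor of ten per unit of this negative logarithm. Compound 1, `COc1cc(C(=O)NS(=O)(=O)c2ccccc2C)ccc1Cc1cn(C)c2ccc(C(=O)NCC3CCCC3)cc12`, gives 8.4 in this assay. Compound 2, `COc1cc(C(=O)NS(=O)(=O)c2ccccc2C)ccc1Cc1cn(C)c2ccc(C(=O)NCC(C)C)cc12`, gives 8.6 in this assay. Compound 3, `CCCn1cc(Cc2ccc(C(=O)NS(=O)(=O)c3ccccc3C)cc2OC)c2cc(C(=O)NCC3CCCC3)ccc21`, gives 8.7 in this assay. A fourth compound, compound 4, `CCCn1cc(Cc2ccc(C(=O)NS(=O)(=O)c3ccccc3C)cc2OC)c2cc(C(=O)NCC(C)C)ccc21`, has not yet been measured.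

Compound 2 differs from compound 1 by one change, (isopropyl in place of cyclopentyl on a saturated chain carbon bound to an amide-type nitrogen), and that change made a step of a number 0.20 log units higher from compound 1 to compound 2 (within the scatter). Compound 3 differs from compound 1 in the core, by ethyl in place of hydrogen on a saturated chain carbon bound to an aromatic nitrogen, with a step of a number 0.30 log units higher from compound 1 to compound 3 (within the scatter). For the measured compounds named here, no step has been worked out between compound 2 and compound 3; their two values differ by less than the usual scatter of the measurement.

Compound 4 differs from compound 3 by isopropyl in place of cyclopentyl on a saturated chain carbon bound to an amide-type nitrogen. Going by the values given here, this is the same change as the one from compound 1 to compound 2, made at the same place, on the core of compound 3 instead of the core of compound 1. The expectation for compound 4 therefore rests on two things: the step of a number 0.20 log units higher from compound 1 to compound 2 (within the scatter), which stayed within the scatter, and the value of compound 3, 8.7, as the starting point. For compound 4 a step of a number 0.20 log units higher from compound 3 to compound 4 (within the scatter) is expected in this assay. Compound 4 is thus estimated at 8.9 in this assay, with a likely range from 8.5 to 9.3.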

Compound 4, negative logarithm of the antagonist equilibrium constant: 9.1
The estimate for compound 4 lay 0.20 log units below the measured number, and the stated range covers the measured number.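

In this assay, isopropyl in place of cyclopentyl on the core of compound 3 gave a step of a number 0.40 log units higher from compound 3 to compound 4 (beyond the scatter), and this agrees with the same change on the core of compound 1: the same change on two cores in this assay, a number 0.20 log units higher (within the scatter) from compound 1 to compound 2 and a number 0.40 log units higher (beyond the scatter) from compound 3 to compound 4, 0.20 log units apart, within the scatter of two such steps. The other change, ethyl in place of hydrogen on a saturated chain carbon bound to an aromatic nitrogen, gave a step of a number 0.50 log units higher from compound 2 to compound 4 (beyond the scatter) with isobutyl on the amide in place of cyclopentylmethyl, and it too agrees with its earlier counterpart: the same change on two cores in this assay, a number 0.30 log units higher (within the scatter) from compound 1 to compound 3 and a number 0.50 log units higher (beyond the scatter) from compound 2 to compound 4, 0.20 log units apart, within the scatter of two such steps. Each change thus carried over between these two cores in the same direction, with no difference beyond the scatter, but this rests on four compounds only, so it does not show that the larger of each pair of steps is a real gain or that either change would carry to any other core.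

The compounds shown leave open whether a tert-butyl or a phenyl group in place of the isopropyl, or an amine or a carboxylic acid at that place, would carry over in the same way. They also leave open what a butyl chain or a benzyl group would do on the aromatic nitrogen.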